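Alkylidene penam esters: cytotoxicity on A-375 cells

The source may hold more compounds than are shown below. What is called first, only, known or untested is meant among the compounds shown, and "the series" means these compounds.

Measured so far, in a functional assay on A-375 cells (Homo sapiens) for cytotoxicity, read by MTT assay, with a stated time of 48 h; on this read-out higher numbers stand for weaker inhibition and lower numbers for stronger inhibition:
- compound 1, `CC1(C)[C@H](C(=O)OC(c2ccccc2)c2ccccc2)N2C(=O)/C(=C/C(=O)c3ccc([N+](=O)[O-])cc3)[C@H]2[S+]1[O-]`, gives 48200 nM
- compound 2, `CCOC(=O)/C=C1/C(=O)N2[C@@H]1SC(C)(C)[C@@H]2C(=O)OC(c1ccccc1)c1ccccc1`, gives 7000 nM
- compound 3, `COC(=O)/C=C1\C[C@H]2SC(C)(C)[C@H](C(=O)OC(c3ccccc3)c3ccccc3)N2C1=O`, gives only a limit of the assay, > 100000 nM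

Compound 2 gives the lowest of the two numbers in this assay; compound 1 gives a higher number, and the gap between them is beyond the scatter. Compound 3 sits at the limit of the assay the limit of > 100000 nM in this assay, at which 1 of the 3 values shown sits, and gives no number. Within the data shown here, no pair of measured compounds differs in only one place, so no single step has been measured.

Compound 4, `CC1(C)S[C@@H]2/C(=C\C(=O)c3ccc(Br)cc3)C(=O)N2[C@H]1C(=O)OC(c1ccccc1)c1ccccc1`, is not yet measured in this assay. Going from compound 2 to compound 4, the change is 4-bromophenyl in place of ethoxy on a carbonyl carbon. Compound 1 also carries an aryl ketone on the carbonyl carbon, but it differs from compound 2 in a second place as well, so its higher number cannot be attributed to the ketone alone. The direction is therefore uncertain; the expectation is a step beyond the scatter toward a higher number, a 2.1-fold higher number from compound 2 to compound 4 (0.33 log units; beyond the scatter). Compound 4 is estimated at 15000 nM, with a range from 4000 nM to 60000 nM.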

Compound 4, half-maximal inhibitory concentration: 29700 nM
Beside the measured number, compound 4's estimate is 2.0-fold (0.30 log units) below it; low and high end bracket the measured number.
By their numbers in this assay, from the lowest: compound 2; then compounds 4 and 1 (each within the scatter of the next). At a limit, above all of these: compound 3.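

In this assay the series now has its first step that changes one place only: a 4.2-fold higher number from compound 2 to compound 4 (0.63 log units; beyond the scatter) with 4-bromophenyl in place of ethoxy on a carbonyl carbon whose other neighbour is a double-bonded chain carbon. Among these compounds, compound 1 also carries an aryl ketone but differs from compound 2 in a second place, so this step is the first direct reading of what the change at this carbonyl carbon does to the number, and here the ethoxycarbonyl compound gives the lower number. Nothing measured on these compounds accounts for the step, and no cause for it can be given from the data at hand.

The step does not separate the loss of the ester oxygen from the arrival of the aryl ring or its bromine, and an unsubstituted phenyl, a methyl or an amine on the same carbonyl carbon would bear on that. Also open, going by these compounds, is how far the ester side can be taken, for instance with a longer chain such as butoxy or with a free carboxylic acid at this position.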